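The compounds below may be only part of what the source reports. "The series", "measured", "known", "first", "only" and "open" are said of these compounds alone.

Compound 1 `O=C(C1CCC(F)(F)CC1)N1CC(c2nc(-c3cccc(Cl)c3)no2)C1` was tested in an assay on HEK293 cells for negative allosteric modulation of metabotropic glutamate receptor 5 (Homo sapiens), read by FLIPR; a lower number here means a stronger inhibitor, a higher number a weaker inhibitor. For compound 1 the assay returns only a limit, > 10000 nM, so among the values shown it stands without a number, at the limit of > 10000 nM in this assay, at which 2 of the 3 values shown sit. Compound 2 `O=C(C1CCC(C(F)(F)F)CC1)N1CC(c2nc(-c3cccc(F)c3)no2)C1` likewise returns only the limit > 10000 nM in this assay. Compound 3 `Cc1cccc(-c2noc(C3CN(S(=O)(=O)c4ccc(F)cc4)C3)n2)c1`, which carries a different group on the ring nitrogen, gives 950 nM in this assay. Compound 4 `O=C(c1ccccc1F)N1CC(c2nc(-c3cccc(Cl)c3)no2)C1` has not yet been measured; it differs from compound 1 by 2-fluorophenyl in place of 4,4-difluorocyclohexyl on a carbonyl carbon. Among the measured compounds shown here, no measured pair shows this exact change. Because compound 3 reaches 950 nM, a gain in inhibition seems plausible. The expected step from compound 1 to compound 4 is an at least 3.3-fold lower number from compound 1 to compound 4 (0.52 log units; beyond the scatter), a move toward measurable inhibition beyond the scatter. Compound 4 is estimated at 3000 nM, between 800 nM and 10000 nM.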

Compound 4, half-maximal inhibitory concentration: 670 nM
Beside the measured number, compound 4's estimate is 4.5-fold (0.65 log units) above it; measured number outside the range, below it.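

At this carbonyl carbon, 2-fluorophenyl in place of 4,4-difluorocyclohexyl gives an at least 14-fold lower number from compound 1 to compound 4 (1.17 log units; beyond the scatter) in this assay, so an amide on this ring nitrogen does not by itself rule out measurable inhibition. Compound 1 returns only a limit, so the true size of this step remains unknown: the limit of > 10000 nM in this assay, at which 2 of the 4 values shown sit.

Still open, as far as these compounds go, is whether the gain comes from the aromatic ring or from its fluorine, which a plain phenyl group on the same carbonyl would help separate. The compounds shown also leave open how a pyridyl ring would fare there.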